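A few compounds are considered here, and "the series" means these few. Any claim that something is new, unique, unknown or untested is made for them only; others in the source may bear on it.

Working notes on the series. Going by the values given here, in a functional assay on cells (leukaemia cell line, Homo sapiens) for inhibition, read by sulforhodamine B assay, with a stated time of 48 h (on this read-out lower numbers stand for stronger inhibition of growth and higher numbers for weaker inhibition of growth), compound 1 `Cc1cc(NS(=O)(=O)c2ccc(-c3cnc(C4CC4)o3)cc2)ccc1Cl` gives 216 nM, the lower of the two numbers so far, and compound 2 `O=S(=O)(Nc1ccc(Br)c(Cl)c1)c1ccc(-c2cnc(C3CC3)o2)cc1` gives 491 nM. Compound 3 `O=S(=O)(Nc1cc(F)cc(Cl)c1)c1ccc(-c2cnc(C3CC3)o2)cc1` keeps the core of compound 1 and carries 3-chloro-5-fluorophenyl in place of 4-chloro-3-methylphenyl on a sulfonamide nitrogen. Among the compounds with values here, only one measured step bears on this change: a 2.3-fold higher number from compound 1 to compound 2 (0.36 log units; beyond the scatter), a modest move at the same place. Within the data shown here, that step replaces a different group, and no measured compound yet carries the 3-chloro-5-fluorophenyl group, so it offers only a rough guide to size. A similarly modest rise in this assay is therefore expected, with no change beyond the scatter also possible. The expected step is a 1.9-fold higher number from compound 1 to compound 3 (0.29 log units; within the scatter). For compound 3 the estimated value is 420 nM, with an expected range of 170 nM to 1050 nM.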

Compound 3, concentration for 50% growth inhibition: 1440 nM
Compound 3: the middle estimate sits 3.4-fold (0.54 log units) below what was measured; the whole stated range lies below it.
By their numbers in this assay, from the lowest: compound 1; then compound 2; then compound 3.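

In this assay, the aryl group on the sulfonamide nitrogen proves more sensitive than compounds 1 and 2 alone indicated: 3-chloro-5-fluorophenyl gives a larger loss (a 6.7-fold higher number from compound 1 to compound 3 (0.82 log units; beyond the scatter)) and also falls short of the 4-bromo-3-chlorophenyl group (a 2.9-fold higher number from compound 2 to compound 3 (0.47 log units; beyond the scatter)). Both steps lie beyond the scatter, which makes compound 3 the weakest of the three, although the entering and leaving groups match in heavy-atom count and in hydrogen-bond donors and acceptors. No evidence on the origin of this loss is available.

The compounds shown do not separate the contribution of the fluorine from that of the chlorine placement, as each step alters more than one substituent at once. Going by these compounds, how a methoxy group or an amine on this phenyl ring would read remains open.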